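Turning the drawn stereocentre from compound 3 to compound 4

A few compounds are considered here, and "the series" means these few. Any claim that something is new, unique, unknown or untested is made for them only; others in the source may bear on it.

Of the compounds shown here, three sharing one core have been measured in an ADME assay on the whole organism with Oryza sativa as the target, tested at 0.1 uM; a lower number here means a stronger effect, a higher number a weaker effect of the compound at the concentration tested. Compound 1 `C[C@H](NC(=O)Nc1cccc(C(F)(F)F)c1)c1ccccc1` gives 94%, compound 2 `C[C@H](NC(=O)Nc1ccccc1F)c1ccccc1` gives 98%, and compound 3 `C[C@@H](NC(=O)Nc1cccc(C(F)(F)F)c1F)c1ccccc1` gives 99%. Compound 3 stands highest of the three numbers, yet its gaps to compound 2 and to compound 1 both lie within the scatter, so no ordering among them can be claimed. Compound 4 `C[C@H](NC(=O)Nc1cccc(C(F)(F)F)c1F)c1ccccc1` has not yet been measured in this assay. It differs from compound 3 as follows: the two compounds have the same atoms and bonds and differ only in configuration as drawn: 1 of 1 stereo elements differ; a stereocentre at a saturated chain carbon is drawn R in compound 3 and S in compound 4. Compound 1 and compound 2 carry the same drawn configuration as compound 4 and sit close to compound 3, so no step beyond the scatter is expected; the estimated step of a number 3 percentage points lower from compound 3 to compound 4 (within the scatter) is small. Compound 4 is expected to give 96%, within 85% to 100%.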

Compound 4, a percentage reported as activity, at one concentration (the size of the read-out at that concentration, not a potency): 99%
Beside the measured number, compound 4's estimate is 3 percentage points below it; the measured number falls inside the stated range.
By their numbers in this assay, from the lowest: compounds 1, 2, 3 and 4 (each within the scatter of the next).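

Turning the stereocentre at the saturated chain carbon gives the first direct test of configuration in this assay, and the outcome is no change at the digits printed from compound 3 to compound 4 (within the scatter). This comparison isolates configuration alone: the fact that compounds 3 and 4 differ only in the configuration as drawn. With the S configuration kept, trifluoromethyl in place of hydrogen on an aromatic carbon gives a number 1 percentage points higher from compound 2 to compound 4 (within the scatter), and fluoro in place of hydrogen on an aromatic carbon gives a number 5 percentage points higher from compound 1 to compound 4 (within the scatter), so neither substitution shows a readable effect here.

As far as these compounds go, whether configuration would matter with an amine or a carboxylic acid in place of trifluoromethyl remains open.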